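The source may report more compounds than this note shows. Statements on the series, on what has been measured and on what is new or still open speak of the compounds shown alone.

Among the measured compounds shown here, compound 1 `CSc1ccc(F)cc1NCC1=NCCN1` is the one fully read member of the set: in an assay on CHO cells for binding affinity to Alpha-2B adrenergic receptor (Homo sapiens), read by radioligand binding (on this read-out lower numbers stand for stronger inhibition and higher numbers for weaker inhibition), compound 1 gives 331 nM. Compound 2 `COc1ccc(SC)c(NCC2=NCCN2)c1` reaches only a limit of the assay, < 6310 nM. Compound 3 `CS(=O)(=O)c1ccc(F)cc1NCC1=NCCN1` likewise shows only a limit, < 6310 nM. Both of these values sit at the limit of < 6310 nM in this assay, at which 2 of the 3 values shown sit. The two measured steps, a step that the limit leaves unreadable from compound 1 to compound 2 and a step that the limit leaves unreadable from compound 1 to compound 3, are unreadable in size and concern other changes than the one now taken. Compound 4 `CS(=O)(=O)c1ccc(C(F)(F)F)cc1NCC1=NCCN1` differs from compound 3 by trifluoromethyl in place of fluoro on an aromatic carbon. No measured step bears on this change, and compound 3 itself is known only as a limit, so no direction beyond the scatter can be expected in this assay from the numbers shown. For compound 4 the expected value is 3000 nM, within 500 nM to 20000 nM. The estimated step is a step that the limit leaves unreadable from compound 3 to compound 4.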

Compound 4, inhibition constant: < 6310 nM
Compound 4: only a limit was reported; the forecaster's own chance of this, stated with the estimate: 50%; the middle value does not contradict the limit.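

Among the compounds shown here, compound 3 and compound 4 are both known only as limits, compound 4 at < 6310 nM in this assay, so no step between them can be read. The compounds shown leave open whether trifluoromethyl in place of fluoro shifts this read-out in either direction.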